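From 4-hydroxyphenyl to 3,4-dichlorophenyl on a shared core

The source may hold more compounds than are shown below. What is called first, only, known or untested is meant among the compounds shown, and "the series" means these compounds.

In a functional assay on MCF7 cells (Homo sapiens) for cytotoxicity, read by MTT assay, with a stated time of 72 h (on this read-out lower numbers stand for stronger inhibition and higher numbers for weaker inhibition), compound 1 (`COc1cccc(/C=C2\CCC/C(=C\c3ccccc3Cl)C2=O)c1OC`) gives 11300 nM and compound 2 (`COc1cccc(/C=C2\CCC/C(=C\c3cccc(Cl)c3)C2=O)c1OC`) gives 12000 nM. Replacing 2-chlorophenyl with 3-chlorophenyl gives a 1.1-fold higher number from compound 1 to compound 2 (0.03 log units; within the scatter).

Compound 3 (`COc1cccc(/C=C2\CCC/C(=C\c3ccc(O)cc3)C2=O)c1OC`) reads > 20000 nM, which is a limit of the assay and not a number.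

Compound 4 (`COc1cccc(/C=C2\CCC/C(=C\c3ccc(Cl)c(Cl)c3)C2=O)c1OC`) differs from it by 3,4-dichlorophenyl in place of 4-hydroxyphenyl on a double-bonded chain carbon bound to a double-bonded ring carbon, with 3,4-dichlorophenyl replacing 4-hydroxyphenyl on a double-bonded chain carbon bound to a double-bonded ring carbon. The closest evidence is the pair of measured steps that replace a chlorophenyl with 4-hydroxyphenyl: an at least 1.7-fold higher number from compound 1 to compound 3 (0.24 log units; that floor lies within the scatter) and an at least 1.6-fold higher number from compound 2 to compound 3 (0.22 log units; that floor lies within the scatter). From the compounds shown here alone, both are only floors, so the true size of the change remains open. Within the data shown here, no measured compound carries 3,4-dichlorophenyl, so compound 4 is expected to read near compound 1 at 11300 nM and compound 2 at 12000 nM, with a modest move toward a lower number than compound 3. The expected change is an at least 2.0-fold lower number from compound 3 to compound 4 (0.30 log units; that floor lies within the scatter). For compound 4, the estimate is 10000 nM, with an expected range of 4500 nM to 20000 nM.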

Compound 4, half-maximal inhibitory concentration: 9000 nM
The estimate for compound 4 lay 1.1-fold (0.05 log units) above the measured number; the measured number falls inside the stated range.
By their numbers in this assay, from the lowest: compounds 4, 1 and 2 (each within the scatter of the next). At a limit, above all of these: compound 3.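

In this assay, 3,4-dichlorophenyl in place of 4-hydroxyphenyl gives an at least 2.2-fold lower number from compound 3 to compound 4 (0.34 log units; beyond the scatter), and this is the only step shown at this position that is printed as beyond the scatter. Compound 3 stands at a limit of the assay and not at a number, so this step is only a floor: the limit of > 20000 nM in this assay, at which 1 of the 4 values shown sits. Adding chloro in place of hydrogen on an aromatic carbon gives a 1.3-fold lower number from compound 2 to compound 4 (0.12 log units; within the scatter), and exchanging 2-chlorophenyl for 3,4-dichlorophenyl gives a 1.3-fold lower number from compound 1 to compound 4 (0.10 log units; within the scatter), so the three chlorinated compounds cannot be told apart.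

The compounds shown leave open how far compound 3 truly lies from the chlorinated compounds, and whether the lower number follows from the chloro groups or from the loss of the hydroxyl. From the compounds shown here alone, it is also open whether an amine or a carboxylic acid on this phenyl ring would read with compound 3 or with the chlorinated compounds.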